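A few compounds are considered here, and "the series" means these few. Any claim that something is new, unique, unknown or untested is made for them only; others in the source may bear on it.

Measured so far:
compound 1 `COc1cc2c(cc1OC)CN(S(=O)(=O)c1ccc(-n3cc(COc4ccc(C=O)cc4)nn3)cc1)CC2`: > 50 ug/mL
compound 2 `O=S(=O)(c1ccc(-n2cc(COc3ccccc3)nn2)cc1)N1CCc2ccccc2C1`: > 50 ug/mL

Both values come from an ADME assay on Vero cells (Chlorocebus sabaeus) for cytotoxicity, with a stated time of 4 days; on this read-out higher numbers stand for weaker inhibition and lower numbers for stronger inhibition. For compound 1 the value given is a limit of the assay, not a number. For compound 2 the value given is likewise a limit. Where compound 1 stands on the numbers shown is therefore only this: it sits at the limit of > 50 ug/mL in this assay, at which 2 of the 2 values shown sit, and nothing separates it from compound 2.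

Compound 3 `COc1cc2c(cc1OC)CN(S(=O)(=O)c1ccc(-n3cc(CO)nn3)cc1)CC2` is not yet measured. It differs from compound 1 by hydrogen in place of 4-formylphenyl on an oxygen on a saturated carbon. For the measured compounds named here, no step between measured compounds exists, so the size of such a change cannot be read from any measured pair. In this assay compound 1 gives only the limit > 50 ug/mL. The step is therefore expected to be none beyond the scatter, with the outcome again most likely a limit. Compound 3 is expected to give 60 ug/mL in this assay, between 30 ug/mL and 120 ug/mL, corresponding to a step that the limit leaves unreadable from compound 1 to compound 3.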

Compound 3, half-maximal inhibitory concentration: > 50 ug/mL
Compound 3: no number, only a limit; the forecaster's own chance of this, stated with the estimate: 85%; the middle value is on the limit's open side.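

No step can be read from compound 1 to compound 3, as each gives only a limit and not a number: the limit of > 50 ug/mL in this assay, at which 3 of the 3 values shown sit.

The compounds shown leave open what number, if any, compound 1, compound 2 or compound 3 would give in this assay and thus what hydrogen in place of 4-formylphenyl does to it.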